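The compounds below may be only part of what the source reports. "The series", "measured", "known", "first", "only" and "open" are said of these compounds alone.

In a functional assay on HCT-116 cells (Homo sapiens) for cytotoxicity, read by MTT assay, with a stated time of 48 h (on this read-out higher numbers stand for weaker inhibition of growth and lower numbers for stronger inhibition of growth), compound 1 (`CC(C)c1nc2cc(Cl)c(Cl)cc2[nH]1`) gives 52000 nM and compound 2 (`CCn1c(C(F)(F)F)nc2cc(Cl)c(Cl)cc21`) gives 95300 nM as its number, and these two values lie within the scatter of each other. Compound 3 (`Nc1ccccc1Cn1c(C(F)(F)F)nc2cc(Cl)c(Cl)cc21`) has not yet been measured. It carries 2-aminophenyl in place of methyl on a saturated chain carbon bound to an aromatic nitrogen and otherwise matches compound 2. For the measured compounds named here, no measured pair shows what such a change does, so any expectation remains loose. Compound 2 at 95300 nM as its number leaves room toward stronger inhibition of growth. In this assay a moderate fall in the number is therefore expected, an estimated step of a 3.2-fold lower number from compound 2 to compound 3 (0.50 log units; beyond the scatter) that would lie somewhat beyond the scatter. In this assay compound 3 is estimated at 30000 nM with an expected range from 8000 nM to 100000 nM overall.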

Compound 3, concentration for 50% growth inhibition: 26100 nM
Estimate against measurement, compound 3: 1.1-fold (0.06 log units) above; the range from low to high includes it.
By their numbers in this assay, from the lowest: compounds 3, 1 and 2 (each within the scatter of the next, the first and the last beyond it).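

In this assay, the change from methyl to 2-aminophenyl on the saturated chain carbon bound to an aromatic nitrogen gives a 3.7-fold lower number from compound 2 to compound 3 (0.56 log units; beyond the scatter), a modest step toward stronger inhibition of growth. For the compounds shown here, this is the first step between compounds differing in one place, and it shows that this position responds to substitution and that the larger group, with its six-membered aromatic ring, does not weaken inhibition of growth here. No measurement available here accounts for the step.

The compounds shown leave open whether the step comes from the aromatic ring or from its amine, which a plain phenyl group would help to separate. They also leave open how a longer chain or a carboxylic acid at this position would compare with methyl and 2-aminophenyl.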